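Aryl substituent changes on the shared indole-linked core

The source may hold more compounds than are shown below. What is called first, only, known or untested is meant among the compounds shown, and "the series" means these compounds.

Compound 3 `CCc1ccc2ccn(CCN3CCCN(C)CC3)c2c1` gives 66% in an assay on HEK293 cells for binding affinity to 5-hydroxytryptamine receptor 7 (Homo sapiens), read by radioligand binding, tested at 1 uM (on this read-out lower numbers stand for less inhibition and higher numbers for more inhibition at the one concentration tested (going by the name of the read-out)), the second highest of the three numbers. Compound 1 `CN1CCCN(CCn2ccc3ccc(F)cc32)CC1` gives 60% in this assay, a difference from compound 3 within the scatter; compound 2 `C#Cc1ccc2ccn(CCN3CCCN(C)CC3)c2c1` gives 79%, so that a number 13 percentage points lower from compound 2 to compound 3 (beyond the scatter). Compound 4 `CN1CCCN(CCn2ccc3ccc(C(C)(C)O)cc32)CC1` differs from compound 3 by 1-hydroxy-1-methylethyl in place of ethyl on an aromatic carbon, at the same aromatic carbon varied in every measured step: a number 19 percentage points higher from compound 1 to compound 2 (beyond the scatter), a number 6 percentage points higher from compound 1 to compound 3 (within the scatter) and a number 13 percentage points lower from compound 2 to compound 3 (beyond the scatter). Those steps were at most modest, and none introduces a hydroxyl, so the direction is open; a step of no more than modest size is expected for compound 4, a number 6 percentage points lower from compound 3 to compound 4 (within the scatter). The estimate for compound 4 in this assay is 60%, with a range from 40% to 80%.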

Compound 4, a percentage reported as inhibition, at one concentration (the size of the read-out at that concentration, not a potency): 6%
Estimate against measurement, compound 4: 54 percentage points above; measured number outside the range, below it.
By their numbers in this assay, from the lowest: compound 4; then compounds 1 and 3 (each within the scatter of the next); then compound 2.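

In this assay, this aromatic carbon had so far shown steps of no more than modest size, and 1-hydroxy-1-methylethyl brings the first large ones: a number 60 percentage points lower from compound 3 to compound 4 (beyond the scatter), a number 73 percentage points lower from compound 2 to compound 4 (beyond the scatter) and a number 54 percentage points lower from compound 1 to compound 4 (beyond the scatter). The position is therefore not indifferent to the group it carries, and the change adds both a hydrogen-bond donor and more heavy atoms than ethyl, so these two differences cannot be told apart here. Nothing available explains the drop. On these data alone, whether the hydroxyl or the branched carbon framework matters remains open. A tert-butyl group or a hydroxymethyl group at this carbon would separate the two.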